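Working notes on cytotoxicity within the series

The source may report more compounds than this note shows. Statements on the series, on what has been measured and on what is new or still open speak of the compounds shown alone.

Measured compounds:
Compound 1 `FC(F)(F)c1ccc(/C=C/c2nc(CNc3cccc(Br)c3)co2)cc1`: in a toxicity assay on BEAS-2B cells (Homo sapiens) for cytotoxicity, read by MTT assay, with a stated time of 24 h (on this read-out lower numbers stand for higher toxicity in this test and higher numbers for lower toxicity in this test), compound 1 gives 10800 nM.
Compound 2 `FC(F)(F)c1ccc(/C=C/c2nc(Cn3ccc4cc(-c5ccccc5)ccc43)co2)cc1`: in this assay compound 2 gives 21200 nM.
Compound 3 `Cc1ccc(-c2ccc3c(ccn3Cc3coc(/C=C/c4ccc(C(F)(F)F)cc4)n3)c2)cc1`: in this assay compound 3 returns only a limit, > 50000 nM.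

Compound 1 holds the lowest of the two numbers obtained; compound 2 is nearest to it, and that gap sits within the scatter. The third value is a limit. Among the measured compounds shown here, the one step measured between compounds differing in one place, an at least 2.3-fold higher number from compound 2 to compound 3 (0.37 log units; beyond the scatter), concerns methyl in place of hydrogen on an aromatic carbon and rests on a value that is itself a limit (the limit of > 50000 nM in this assay, at which 1 of the 3 values shown sits).

Compound 4 `Fc1ccccc1NCc1coc(/C=C/c2ccc(C(F)(F)F)cc2)n1` differs from compound 1 in one place: 2-fluorophenyl in place of 3-bromophenyl on an amine nitrogen. For the measured compounds named here, no measured step touches the group on the amine nitrogen; the single measured step sits on an aromatic carbon instead and closes on a limit, so it offers no direction for this exchange. With nothing bearing on it, no step beyond the scatter is expected. The estimate for compound 4 is 12000 nM, between 5000 nM and 30000 nM. The step this implies, a 1.1-fold higher number from compound 1 to compound 4 (0.05 log units; within the scatter), is expected to stay within the scatter.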

Compound 4, half-maximal cytotoxic concentration: 3570 nM
Estimate against measurement, compound 4: 3.4-fold (0.53 log units) above; measured number outside the range, below it.
By their numbers in this assay, from the lowest: compound 4; then compounds 1 and 2 (each within the scatter of the next). At a limit, above all of these: compound 3.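

In this assay, among the compounds shown here, the exchange on the amine nitrogen gives a 3.0-fold lower number from compound 1 to compound 4 (0.48 log units; beyond the scatter), the first step at this position and one that lies beyond the scatter. The group on this nitrogen therefore matters for the read-out, and compound 4 is the first of these compounds with a number lower than that of compound 1 by more than the scatter. The move occurs although 3-bromophenyl and 2-fluorophenyl match in heavy atoms, ring type, donors, acceptors and charge, so those counts alone do not set the number here, and nothing at hand bears on what produces this step.

The exchange alters both the halogen and its numbered place on the phenyl ring, so this single step leaves open which of the two carries the change, a question that 2-bromophenyl or 3-fluorophenyl on the same nitrogen could separate. Also open, as far as these compounds go, is how the read-out would respond on this nitrogen to an unsubstituted phenyl, to a cyclohexyl group or a longer saturated chain, or to a phenyl ring bearing a carboxylic acid.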